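A few compounds are considered here, and "the series" means these few. Any claim that something is new, unique, unknown or untested is made for them only; others in the source may bear on it.

Measured compounds:
compound 1 `Cc1cc2c(C(C)C)ccc(C)c2cc1OC(=O)c1cccc(C(F)(F)F)c1`, a functional assay on U-251 cells (Homo sapiens) for antiproliferative activity, read by sulforhodamine B assay, with a stated time of 48 h, tested at 50 uM; on this read-out lower numbers stand for less inhibition and higher numbers for more inhibition at the one concentration tested (going by the name of the read-out): "not active" (no number reported)
compound 2 `CC1=CC[C@H](C(C)C)c2cc(C)c(OC(=O)c3cccc(C(F)(F)F)c3)cc21`, this assay: 29.3%
compound 3 `CC1=CC[C@H](C(C)C)c2cc(C)c(OC(=O)c3cccc(Cl)c3)cc21`, this assay: 0.9%

Compound 1 stands without a single number in this assay; only the statement that compound 1 is not active is recorded, so no quantitative position can be given for it among the measured compounds.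

Compound 4 `COc1cccc(C(=O)Oc2cc3c(C)ccc(C(C)C)c3cc2C)c1` differs from compound 1 in one place: methoxy in place of trifluoromethyl on an aromatic carbon. For the measured compounds named here, no measured step exchanges a trifluoromethyl for a methoxy. The nearest measured step exchanges the trifluoromethyl for a chloro on the core of compound 2, not the core of compound 1: a number 28.4 percentage points lower from compound 2 to compound 3 (beyond the scatter). That step points downward, and its size is modest. Compound 1 gives no number to move from, so a further fall cannot be read off, and a step in this assay from compound 1 to compound 4 cannot be sized; a low read-out is expected either way.

Compound 4 is expected to give about 5% in this assay, in the range 0% to 20%, with a fair chance that again only "not active" is recorded.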

Compound 4, a percentage reported as inhibition, at one concentration (the size of the read-out at that concentration, not a potency): "not active" (no number reported)
The entry for compound 4 holds no number; there is nothing to compare the estimate with.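

No step can be read from compound 1 to compound 4: in this assay compound 1 gives "not active" (no number reported) and compound 4 gives "not active" (no number reported) with no number on either side. The compounds shown leave open how methoxy in place of trifluoromethyl acts on the core of compound 2. No evidence bears on these results.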